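The compounds below may be only part of what the source reports. "The series", "measured", "known", "first", "only" and "open" are said of these compounds alone.

Of the compounds shown here, three built on one shared core have been measured in a functional assay on MDA-MB-231 cells (Homo sapiens) for cytotoxicity, read by MTT assay, with a stated time of 72 h; a lower number here means a stronger inhibitor, a higher number a weaker inhibitor. Compound 1 `O=C1c2c[n+]([O-])c3ccccc3c2C(=O)c2c1c1ccccc1n2Cc1cn([C@@H]2C[C@H](O)[C@@H](CO)O2)nn1` gives 130 nM in this assay. Compound 2 `CC1(C)OCC(Cn2cc(Cn3c4c(c5ccccc53)C(=O)c3c[n+]([O-])c5ccccc5c3C4=O)nn2)O1` gives 230 nM in this assay; the step of a 1.8-fold higher number from compound 1 to compound 2 (0.25 log units; within the scatter) concerns a group on an aromatic nitrogen and not the chain that matters here. Compound 3 `O=C1c2c[n+]([O-])c3ccccc3c2C(=O)c2c1c1ccccc1n2CCN1CCCC1` gives 630 nM in this assay, the highest of the three numbers, standing beyond the scatter above both compound 2 and compound 1.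

Compound 4 `O=C1c2c[n+]([O-])c3ccccc3c2C(=O)c2c1c1ccccc1n2CCCN1CCC(O)CC1` has not yet been measured. It differs from compound 3 by (4-hydroxypiperidin-1-yl)methyl in place of pyrrolidin-1-yl on a saturated chain carbon, two bonds along the chain from an aromatic nitrogen. Within the data shown here, no measured step touches this part of the molecule: the single step available, a 1.8-fold higher number from compound 1 to compound 2 (0.25 log units; within the scatter), alters a substituent on an aromatic nitrogen and lies within the scatter, so it offers no guide to how the exchange of pyrrolidin-1-yl for (4-hydroxypiperidin-1-yl)methyl on the saturated chain carbon will read in this assay. With nothing bearing on the change, the expected step of a 1.1-fold lower number from compound 3 to compound 4 (0.02 log units; within the scatter) is none beyond the scatter. Compound 4 is therefore estimated at 600 nM in this assay, with a range from 250 nM to 1500 nM that leaves room for a modest gain or a modest loss.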

Compound 4, half-maximal inhibitory concentration: 280 nM
Beside the measured number, compound 4's estimate is 2.1-fold (0.33 log units) above it; measured number inside the range.
By their numbers in this assay, from the lowest: compounds 1, 2 and 4 (each within the scatter of the next, the first and the last beyond it); then compound 3.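

In this assay, the exchange of 2-(pyrrolidin-1-yl)ethyl for 3-(4-hydroxypiperidin-1-yl)propyl on the aromatic nitrogen gives a 2.3-fold lower number from compound 3 to compound 4 (0.35 log units; beyond the scatter), a modest step and the only one shown that changes this amine-bearing chain. It shows that this place responds to the exchange and that the reading in this assay does not worsen when the five-membered ring gives way to the larger group with a six-membered ring and a hydroxy group, which adds a hydrogen-bond donor. No evidence is at hand that accounts for the size or direction of this step.

Since the chain length, the ring size and the hydroxy group all change in one step, the compounds shown leave open which of them carries the difference, a question that a 3-(pyrrolidin-1-yl)propyl chain, a 2-(4-hydroxypiperidin-1-yl)ethyl chain or a 3-(piperidin-1-yl)propyl chain could help to separate. Also open, from the compounds shown here alone, is how a morpholine ring or a carboxylic acid in this place would read in the same assay.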